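A few compounds are considered here, and "the series" means these few. Any claim that something is new, unique, unknown or untested is made for them only; others in the source may bear on it.

Compound 1 `CC(=O)CC/C=C(\C)CCC1=C(C)CCCC1(C)C`, compound 2 `C=C1CCCC(C)(C)C1(O)CC/C(C)=C/CC[C@]1(C)CC[C@@H]([C@@H](C)C(=O)OC)OO1`, compound 3 `C=C1CCCC(C)(C)C1CC[C@@]1(C)CC[C@H]([C@@H](C)C(=O)O)OO1`.

In a functional assay on A549 cells (Homo sapiens) for inhibition (a lower number here means a stronger inhibitor of growth, a higher number a weaker inhibitor of growth), compound 1 gives > 15000 nM, which is a limit of the assay and not a number. Compound 2 gives > 17500 nM in this assay, again a limit. Going by the values given here, compound 3 gives 3050 nM in this assay, the only measured number among the three. The other two values sit at the limit of > 15000 nM in this assay, at which 1 of the 3 values shown sits, and at the limit of > 17500 nM in this assay, at which 1 of the 3 values shown sits. Among the compounds with values here, compound 4 `C=C1CCCC(C)(C)C1CC[C@]1(C)CC[C@@H]([C@@H](C)C(=O)O)OO1` has not yet been measured. the two compounds have the same atoms and bonds; at least one stereo element is drawn with a configuration in one of them and without one in the other: 2 of 4 stereo elements differ; a stereocentre at a saturated ring carbon is drawn S in compound 3 and R in compound 4; a stereocentre at a saturated ring carbon is drawn R in compound 3 and S in compound 4 No measured pair shows what such a change does in this assay, so the step could lie in either direction and beyond the scatter, with weaker growth inhibition somewhat more likely. Compound 4 is therefore expected to give about 6000 nM, between 1500 nM and 25000 nM, an expected step of a 2.0-fold higher number from compound 3 to compound 4 (0.29 log units; within the scatter).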

Compound 4, concentration for 50% growth inhibition: > 10000 nM
Compound 4: no number, only a limit; the forecaster's own chance of this, stated with the estimate: 25%; middle value at least 1.6-fold (0.22 log units) from the limit.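

Going by these compounds alone, compounds 3 and 4 have the same atoms and bonds and differ only in the configuration at two saturated ring carbons, so this pair is the first to show what such a change does. In this assay the step is an at least 3.2-fold higher number from compound 3 to compound 4 (0.51 log units; beyond the scatter), meaning that inverting these two stereocentres together weakens growth inhibition by more than the usual scatter. Compound 4 gives > 10000 nM, which is a limit of the assay and not a number.

As far as these compounds go, it remains open whether inverting only one of the two stereocentres would be enough. From the compounds shown here alone, it is also open whether the same preference would hold with an amide in place of the carboxylic acid.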